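The source may hold more compounds than are shown below. What is called first, only, known or untested is meant among the compounds shown, and "the series" means these compounds.

Measured compounds in a functional assay on K562 cells (Homo sapiens) for antiproliferative activity, read by MTT assay, with a stated time of 72 h; on this read-out lower numbers stand for stronger inhibition and higher numbers for weaker inhibition:
- compound 1 `COc1cc(C(=O)c2sc3ccccc3c2-c2ccc(Cl)cc2)cc(OC)c1OC`: 4200 nM
- compound 2 `COc1ccc(OC)c(-c2c(C(=O)c3cc(OC)c(OC)c(OC)c3)sc3ccccc23)c1`: > 10000 nM; this is a limit of the assay, not a number
- compound 3 `COc1cc(C(=O)c2sc3ccccc3c2Nc2ccccc2)cc(OC)c1OC`: 2300 nM

Compound 1 stands among the two numbers read with compound 3 as its nearest neighbour; the step of a 1.8-fold lower number from compound 1 to compound 3 (0.26 log units; within the scatter) lies within the scatter, so the two are not separated. Going by the values given here, the only value beyond is the limit at which compound 2 sits (the limit of > 10000 nM in this assay, at which 1 of the 3 values shown sits), and the steps of an at least 2.3-fold higher number from compound 1 to compound 2 (0.37 log units; beyond the scatter) and an at least 4.3-fold lower number from compound 2 to compound 3 (0.63 log units; beyond the scatter) are both beyond the scatter.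

Compound 4 `COc1ccc(Nc2c(C(=O)c3cc(OC)c(OC)c(OC)c3)sc3ccccc23)cc1` differs from compound 1 by (4-methoxyphenyl)amino in place of 4-chlorophenyl on an aromatic carbon. The step that bears most directly on it is the exchange to an anilino group, a 1.8-fold lower number from compound 1 to compound 3 (0.26 log units; within the scatter), which stayed within the scatter. The two steps involving compound 2 concern a 2,5-dimethoxyphenyl group and do not carry over to a (4-methoxyphenyl)amino group; they are noted but not used. Added methoxy groups, as in compound 2, have not been tested on the anilino pattern, so no further shift is assumed.

For compound 4 the expectation is therefore a number close to compound 1 and compound 3, with no step beyond the scatter: the estimated step is a 1.4-fold lower number from compound 1 to compound 4 (0.15 log units; within the scatter). The expected value for compound 4 is 3000 nM, in the range 900 nM to 10000 nM.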

Compound 4, half-maximal inhibitory concentration: 2900 nM
Compound 4: middle estimate off by 1.0-fold (0.01 log units), on the high side, and the stated range covers the measured number.
By their numbers in this assay, from the lowest: compounds 3, 4 and 1 (each within the scatter of the next). At a limit, above all of these: compound 2.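

In this assay, a (4-methoxyphenyl)amino group on this aromatic carbon of the five-membered ring is not separated from 4-chlorophenyl, a 1.4-fold lower number from compound 1 to compound 4 (0.16 log units; within the scatter), and methoxy in place of hydrogen on the anilino group also leaves the read-out within the scatter, a 1.3-fold higher number from compound 3 to compound 4 (0.10 log units; within the scatter). Set against the 2,5-dimethoxyphenyl group, the change gives an at least 3.4-fold lower number from compound 2 to compound 4 (0.53 log units; beyond the scatter), so a methoxy group on the entering aromatic ring does not by itself bring the read-out to that limit, although this pair differs in the amino link as well as in the methoxy pattern. Compound 2 stands at a limit of the assay, not a number: the limit of > 10000 nM in this assay, at which 1 of the 4 values shown sits.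

The compounds shown do not separate the contribution of the amino link from that of the number and placing of the methoxy groups. Also open, on these data alone, is how this position responds to a morpholine or a carboxylic acid on the entering group, and whether any group here moves the read-out beyond the scatter below the level shared by compound 1, compound 3 and compound 4.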